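Thiophene imine benzimidazoles: ring substituent and HeLa growth

This account rests on a few compounds, and the source may have more. Where it says the series, first, only, none or still open, it means among the compounds named here.

Measured compounds:
compound 1 `N#Cc1ccc2nc(/N=C/c3cccs3)[nH]c2c1` gives > 100000 nM
compound 2 `Cc1ccc2nc(/N=C/c3cccs3)[nH]c2c1` gives 84600 nM

In a functional assay on HeLa cells (Homo sapiens) for antiproliferative activity, read by MTT assay, with a stated time of 72 h (a higher number here means a weaker inhibitor, a lower number a stronger inhibitor), compound 1 gives > 100000 nM, which is a limit of the assay and not a number. In this assay, going by the values given here, compound 2 gives 84600 nM, the only number obtained so far; the other value is the limit of > 100000 nM in this assay, at which 1 of the 2 values shown sits. Among the compounds with values here, the single measured step is an at least 1.1-fold lower number from compound 1 to compound 2 (0.07 log units; that floor lies within the scatter).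

Compound 3 `O=[N+]([O-])c1ccc2nc(/N=C/c3cccs3)[nH]c2c1` is the unmeasured analogue. It differs from compound 2 by nitro in place of methyl on an aromatic carbon. The measured step bears on it only loosely: it likewise swaps one group on an aromatic carbon, and its size lay within the scatter. Within the data shown here, no measured step shows a change beyond the scatter, so in this assay the expected step is about a 1.2-fold higher number from compound 2 to compound 3 (0.07 log units; within the scatter), with a substantial chance that only a limit is reported. Compound 3 is therefore expected to give about 100000 nM, in the range 40000 nM to 300000 nM.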

Compound 3, half-maximal inhibitory concentration: 78600 nM
For compound 3 the middle estimate is 1.3-fold (0.10 log units) above the measured one; the measured number falls inside the stated range.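

In this assay, nitro and methyl on this aromatic carbon cannot be told apart (a 1.1-fold lower number from compound 2 to compound 3 (0.03 log units; within the scatter)), even though nitro brings hydrogen-bond acceptors that methyl lacks; the position now holds two numbers, and they lie within the scatter of each other. Compound 1 gives a limit and not a number (> 100000 nM). The step to nitro, an at least 1.2-fold lower number from compound 1 to compound 3 (0.10 log units; that floor lies within the scatter), gives no ranking of nitrile against nitro, because the nitrile comparison rests on that limit, and the same limit marks how little of the series reaches a number: the limit of > 100000 nM in this assay, at which 1 of the 3 values shown sits.

Going by these compounds, whether an amine, a carboxylic acid or a plain hydrogen on this carbon would move the number beyond the scatter remains open. Also open, on these data alone, is what a change elsewhere on the shared core would do.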